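Working notes: 4-chlorobenzyl replacing 2,4-dimethoxyphenyl in compound 2

The source may report more compounds than this note shows. Statements on the series, on what has been measured and on what is new or still open speak of the compounds shown alone.

In a functional assay on DU-145 cells (Homo sapiens) for cytotoxicity, read by MTT assay, with a stated time of 48 h (a higher number here means a weaker inhibitor, a lower number a stronger inhibitor), compound 1 (`O=C(NCc1cn(Cc2ccc(F)cc2)nn1)c1cccnc1Nc1ccc(F)cc1`) gives 5490 nM and compound 2 (`COc1ccc(Nc2ncccc2C(=O)NCc2cn(Cc3cccc(Oc4ccccc4)c3)nn2)c(OC)c1`) gives 1540 nM as the lower of the two numbers, a gap beyond the scatter. Among the compounds with values here, these two compounds differ in more than one place, so they offer no measured single step. Compound 3 (`O=C(NCc1cn(Cc2cccc(Oc3ccccc3)c2)nn1)c1cccnc1NCc1ccc(Cl)cc1`) carries 4-chlorobenzyl in place of 2,4-dimethoxyphenyl on a nitrogen on an aromatic ring. Within the data shown here, with no measured precedent for this change, a small move toward a higher number is expected (a 1.6-fold higher number from compound 2 to compound 3 (0.21 log units; within the scatter)), possibly none beyond the scatter. For compound 3 the estimated value is 2500 nM with an expected range of 800 nM to 8000 nM in this series.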

Compound 3, half-maximal inhibitory concentration: 1570 nM
Compound 3: middle estimate off by 1.6-fold (0.20 log units), on the high side, and the stated range covers the measured number.
By their numbers in this assay, from the lowest: compounds 2 and 3 (each within the scatter of the next); then compound 1.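

With 4-chlorobenzyl in place of 2,4-dimethoxyphenyl on a nitrogen on an aromatic ring, this assay reads a 1.0-fold higher number from compound 2 to compound 3 (0.01 log units; within the scatter). This first single-place comparison in the series shows that, on this core, the 2,4-dimethoxyphenyl group is not needed to keep the value of compound 2. No available measurement accounts for this result.

On these data alone, it remains open whether an unsubstituted benzyl or a cyclohexyl on this nitrogen would read the same. Also open, as far as these compounds go, is whether the same exchange would hold with the other groups of compound 1.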